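The source may hold more compounds than are shown below. What is called first, only, known or untested is meant among the compounds shown, and "the series" means these compounds.

Measured so far:

Compound 1, `N#Cc1ccc(NC(=O)c2cccc(Br)c2O)cc1`, gives 3260 nM in a functional assay on KG-1 cells (Homo sapiens) for cytotoxicity, read by luminescence and CellTiter-Glo, with a stated time of 3 days; a lower number here means a stronger inhibitor, a higher number a weaker inhibitor.
Compound 2, `O=C(Nc1ccc([N+](=O)[O-])cc1)c1cc(F)ccc1O`, gives 1100 nM in this assay.
Compound 3, `N#Cc1ccc(NC(=O)c2ccc3cccnc3c2O)cc1`, gives 2320 nM in this assay.

Compound 1 has the highest number of the three in this assay, meaning it is the weakest inhibitor of the set. Compound 3 is closest to it, and that gap lies within the scatter, so the two cannot be told apart. Compound 2 stands well below compound 1, and that gap is beyond the scatter.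

Compound 4, `N#Cc1ccc(NC(=O)c2ccccc2O)cc1`, has not yet been measured. It differs from compound 1 in a single place: hydrogen in place of bromo on an aromatic carbon. Among the measured compounds shown here, nothing among the measured compounds shows this same change, so no measured step can guide the estimate directly. Removing a substituent from the core is expected to shift the number upward by a modest amount, possibly beyond the scatter, with compound 4 expected to be a somewhat weaker inhibitor than compound 1; the expected step is a 2.0-fold higher number from compound 1 to compound 4 (0.30 log units; within the scatter). Compound 4 is expected to give about 6500 nM in this assay, within a range from 2200 nM to 20000 nM.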

Compound 4, half-maximal inhibitory concentration: 5370 nM
The estimate for compound 4 lay 1.2-fold (0.08 log units) above the measured number; the measured number falls inside the stated range.
By their numbers in this assay, from the lowest: compound 2; then compounds 3, 1 and 4 (each within the scatter of the next, the first and the last beyond it).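

Replacing bromo with hydrogen on this aromatic carbon, ortho to a hydroxy group, gives a 1.6-fold higher number from compound 1 to compound 4 (0.22 log units; within the scatter) in this assay. Among the compounds shown here, this is the first direct look at this position, and compound 1 and compound 4 cannot be told apart, so bromo at this place is not needed for the activity seen with compound 1. Nothing shown offers a measured reason for this result.

The compounds shown compare only bromo and hydrogen at this position, so it remains open whether a different group, such as an amine, a methoxy group or a carboxylic acid, would move the number beyond the scatter. From the compounds shown here alone, it also remains open whether the same swap would read alike on a core carrying a nitro group instead of the nitrile.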